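This account rests on a few compounds, and the source may have more. Where it says the series, first, only, none or still open, it means among the compounds named here.

Compound 1 `CC(C)n1nc(-c2ccc3oc(N)nc3c2)c2c(CO)nc(N)nc21` stands in this set only as a limit rather than a number: in an ADME assay on microsomes from liver (Homo sapiens) for metabolic stability, read by LC-MS, with a stated time of 15 min, tested at 1 uM, in the presence of a further agent that is not named here (a higher number here means that more of the compound is left, a lower number that less of the compound is left), compound 1 gives > 95%, which is a limit of the assay (the limit of > 95% in this assay, at which 1 of the 3 values shown sits). Compound 2 `CC(C)n1nc(-c2ccc3oc(N)nc3c2)c2c(F)nc(N)nc21` gives 83% in this assay, and compound 3 `CC(C)n1nc(-c2ccc3oc(N)nc3c2)c2c(Br)nc(N)nc21` gives 94%. The measured steps from the hydroxymethyl parent are a number at least 12 percentage points lower from compound 1 to compound 2 (beyond the scatter) and a number at least 1 percentage points lower from compound 1 to compound 3 (that floor lies within the scatter); between the two halogens the step is a number 11 percentage points higher from compound 2 to compound 3 (beyond the scatter). Compound 4 `CC(C)n1nc(-c2ccc3oc(N)nc3c2)c2c(C#N)nc(N)nc21` carries cyano in place of hydroxymethyl on an aromatic carbon. Because a number at least 12 percentage points lower from compound 1 to compound 2 (beyond the scatter) lay beyond the scatter while a number at least 1 percentage points lower from compound 1 to compound 3 (that floor lies within the scatter) did not, compound 4 is expected to show a number at least 7 percentage points lower from compound 1 to compound 4 (that floor lies within the scatter). Compound 4 is therefore estimated at 88%, with a range from 74% to 96%.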

Compound 4, percent of the compound remaining: > 95%
Compound 4 was reported as a limit (the forecaster's own chance of this, stated with the estimate: 25%); at least 7 percentage points between middle value and limit.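

In this assay compound 4 gives > 95%, a limit of the assay. Cyano in place of fluoro gives a number at least 12 percentage points higher from compound 2 to compound 4 (beyond the scatter), whereas cyano in place of bromo gives only a number at least 1 percentage points higher from compound 3 to compound 4 (that floor lies within the scatter), so at this aromatic carbon compound 2 alone stands apart from the other compounds. The step between compound 1 and compound 4 cannot be read, since both sit at the limit: the limit of > 95% in this assay, at which 2 of the 4 values shown sit.

On these data alone, the order among compound 1, compound 3 and compound 4 remains open. So does the outcome of an amine or a carboxylic acid at this aromatic carbon.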